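Mirror-image pair: compound 1 against compound 3

A few compounds are considered here, and "the series" means these few. Any claim that something is new, unique, unknown or untested is made for them only; others in the source may bear on it.

Among the compounds with values here, compound 1 `O[C@H]1[C@H](CCCc2ccccc2)NC[C@@H]1O` holds the higher of the two numbers measured so far: in an assay on lysosomes for inhibition of Maltase-glucoamylase (Homo sapiens), read by spectrophotometry, tested at 1000 uM (a higher number here means more inhibition at the concentration tested (going by the name of the read-out), a lower number less inhibition), compound 1 gives 27.8%, while compound 2 `Cc1ccc([C@H]2NC[C@@H](O)[C@@H]2O)cc1` gives 15% in this assay, a gap beyond the scatter. Compound 3 `O[C@H]1[C@H](O)CN[C@@H]1CCCc1ccccc1` is the mirror image of compound 1: the two compounds have the same atoms and bonds and differ only in configuration as drawn: 3 of 3 stereo elements differ (all stereocentres are inverted: mirror images); a stereocentre at a saturated ring carbon is drawn S in compound 1 and R in compound 3; a stereocentre at a saturated ring carbon is drawn S in compound 1 and R in compound 3; a stereocentre at a saturated ring carbon is drawn S in compound 1 and R in compound 3. Within the data shown here, no measured pair shows what such an inversion does, so the direction rests on expectation alone. A loss of inhibition is expected, as the step of a number 12.8 percentage points lower from compound 1 to compound 3 (beyond the scatter), with a wide range. For compound 3 the expected value in this assay is 15%, range 2% to 45%.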

Compound 3, a percentage reported as inhibition, at one concentration (the size of the read-out at that concentration, not a potency): 26.5%
The estimate for compound 3 lay 11.5 percentage points below the measured number; the range from low to high includes it.
By their numbers in this assay, from the lowest: compound 2; then compounds 3 and 1 (each within the scatter of the next).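

In this assay, within the data shown here, inverting all three stereocentres gives a number 1.3 percentage points lower from compound 1 to compound 3 (within the scatter), the first reading of such an inversion. For this pair, the drawn configuration therefore shows no effect beyond the scatter at the concentration tested. The comparison isolates configuration alone: the fact that compounds 1 and 3 differ only in the configuration as drawn.

Going by these compounds, both numbers come from a single concentration, so the potency of each mirror image remains unknown. Also open, on these data alone, are inversion of a single stereocentre and whether the same result holds with a shorter chain or a carboxylic acid in place of the phenyl ring.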